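The compounds below may be only part of what the source reports. "The series", "measured", "known", "first", "only" and "open" are said of these compounds alone.

Of the compounds shown here, three sharing one core have been measured in a functional assay (blood) for inhibition, with Homo sapiens as the target; on this read-out lower numbers stand for stronger inhibition and higher numbers for weaker inhibition. Compound 1 `C/C(=N\OCCSc1nnnn1C)c1ccc(Sc2cc(F)cc(C3CCOCC3)c2)cc1` gives 120 nM, compound 2 `CO/N=C(\C)c1ccc(Sc2cc(F)cc(C3CCOCC3)c2)cc1` gives 110 nM and compound 3 `CS/C(=N\O)c1ccc(Sc2cc(F)cc(C3CCOCC3)c2)cc1` gives 190 nM. Compound 3 thus carries the highest of the three numbers, yet both gaps to it lie within the scatter, so the three cannot be told apart. Compound 4 `C/C(=N\OCC(=O)O)c1ccc(Sc2cc(F)cc(C3CCOCC3)c2)cc1` differs from compound 3 by a group of 8 heavy atoms (4 carbon, 1 nitrogen, 3 oxygen; no ring) in place of a group of 5 heavy atoms (2 carbon, 1 nitrogen, 1 oxygen, 1 sulfur; no ring), on an aromatic carbon. Among the compounds with values here, two measured steps bear on this change: a 1.7-fold higher number from compound 2 to compound 3 (0.24 log units; within the scatter) alters the same aromatic carbon, and a 1.1-fold lower number from compound 1 to compound 2 (0.04 log units; within the scatter) alters the chain on the oxygen. Neither moved the number beyond the scatter, so no step beyond the scatter is expected here, with a 1.3-fold lower number from compound 3 to compound 4 (0.10 log units; within the scatter) as the estimated step. Compound 4 is expected to give about 150 nM, between 50 nM and 450 nM.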

Compound 4, half-maximal inhibitory concentration: 740 nM
Beside the measured number, compound 4's estimate is 4.9-fold (0.69 log units) below it, outside the stated range (above it).
By their numbers in this assay, from the lowest: compounds 2, 1 and 3 (each within the scatter of the next); then compound 4.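

In this assay, the chain on the oxygen turns out to matter: carboxy in place of hydrogen gives a 6.7-fold higher number from compound 2 to compound 4 (0.83 log units; beyond the scatter), and carboxy in place of ((1-methyl-1H-tetrazol-5-yl)sulfanyl)methyl gives a 6.2-fold higher number from compound 1 to compound 4 (0.79 log units; beyond the scatter), both towards weaker inhibition, although the earlier change on this chain stayed within the scatter. The change at the aromatic carbon points the same way, with a 3.9-fold higher number from compound 3 to compound 4 (0.59 log units; beyond the scatter). Nothing available explains this loss. Still open, as far as these compounds go, is whether an amine or a methyl ester in place of the carboxy group would restore the number, and how a longer chain carrying the carboxy group would read.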